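Methoxy to Hydroxy on a Pyrazole Growth Inhibitor

The source may report more compounds than this note shows. Statements on the series, on what has been measured and on what is new or still open speak of the compounds shown alone.

Measured compounds:
Compound 1, `COc1cc(C)cc(-c2c(-c3ccnc(-c4ccc(N(C)C)cc4)c3)cnn2CC#N)c1`: 40900 nM
Compound 2, `COc1cc(C)cc(-c2nn(CC#N)cc2-c2ccnc(-c3ccc(N(C)C)cc3)c2)c1`: 30100 nM
Compound 3, `COc1cc(C)cc(-c2nn(CC#N)cc2-c2ccc(-c3cccc(C(C)=O)c3)nc2)c1`: 10400 nM

Of the compounds shown here, three sharing a common core have been tested in a functional assay on IGROV-1 cells (Homo sapiens) for inhibition, read by sulforhodamine B assay, with a stated time of 48 h; a higher number here means a weaker inhibitor of growth, a lower number a stronger inhibitor of growth. Compound 2 gives 30100 nM there, which places it second highest of the three numbers. Its nearest neighbour is compound 1, whose value of 40900 nM lies within the usual scatter of such measurements, so no order between compound 1 and compound 2 can be claimed. Compound 3, with 10400 nM, sits clearly lower than compound 2, beyond the scatter.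

The next compound, compound 4, `Cc1cc(O)cc(-c2nn(CC#N)cc2-c2ccnc(-c3ccc(N(C)C)cc3)c2)c1`, is not yet measured in this assay. It differs from compound 2 in one place: hydrogen in place of methyl on an oxygen on an aromatic ring

Within the data shown here, nothing among the measured compounds shows how this particular change behaves, so there is no step to lean on. The expectation is therefore a step of a 1.0-fold lower number from compound 2 to compound 4 (0.00 log units; within the scatter) for the move to compound 4, essentially no change beyond the scatter. Compound 4 is accordingly estimated at 30000 nM, with a plausible range from 10000 nM to 100000 nM.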

Compound 4, concentration for total growth inhibition: 24800 nM
For compound 4 the middle estimate is 1.2-fold (0.08 log units) above the measured one; measured number inside the range.
By their numbers in this assay, from the lowest: compound 3; then compounds 4, 2 and 1 (each within the scatter of the next).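

In this assay the move from methoxy to hydroxy on the aromatic ring gives a 1.2-fold lower number from compound 2 to compound 4 (0.08 log units; within the scatter) and so shows no change that can be told apart from the scatter. Among these compounds, this is the first direct reading at this oxygen, since no earlier pair of compounds differed in one place, and it shows that in this pair the methyl on the oxygen can be replaced by hydrogen without a measurable shift in growth inhibition. No other information at hand bears on this result.

The compounds shown leave open whether a longer chain on the same oxygen, or an amine or a carboxylic acid in place of the hydroxy, would also leave the number unchanged. They also leave open whether methoxy to hydroxy behaves the same way on the cores of compound 1 and compound 3.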